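Aryl substitution on the dihydropyridine acid series

A few compounds are considered here, and "the series" means these few. Any claim that something is new, unique, unknown or untested is made for them only; others in the source may bear on it.

Measured compounds:
compound 1 `COC(OC)C1=C(C(=O)OC/C=C/c2ccccc2)C(c2cccc(Cl)c2)C(C(=O)O)=CN1` — 1100 nM
compound 2 `COC(OC)C1=C(C(=O)OC/C=C/c2ccccc2)C(c2ccc(Cl)cc2)C(C(=O)O)=CN1` — 1100 nM
compound 3 `COc1ccc(C2C(C(=O)O)=CNC(C(OC)OC)=C2C(=O)OC/C=C/c2ccccc2)cc1Cl` — 1500 nM

All three share one core and differ only in the aryl group on a saturated ring carbon. In an assay on IMR-32 cells for inhibition of Voltage-dependent N-type calcium channel subunit alpha-1B (Homo sapiens), with a stated time of 5 min (a higher number here means a weaker inhibitor, a lower number a stronger inhibitor), compound 3 gives the highest of the three numbers, but its gap to compound 1 and to compound 2 is within the scatter, so no order among them can be read. Moving the chloro, no change at the digits printed from compound 1 to compound 2 (within the scatter); adding a methoxy, a 1.4-fold higher number from compound 1 to compound 3 (0.13 log units; within the scatter); the combined change, a 1.4-fold higher number from compound 2 to compound 3 (0.13 log units; within the scatter).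

Compound 4 `COc1c(Cl)cc(C2C(C(=O)O)=CNC(C(OC)OC)=C2C(=O)OC/C=C/c2ccccc2)cc1Cl` is not yet measured. Relative to compound 3 it carries chloro in place of hydrogen on an aromatic carbon. The nearest precedents are the chloro repositioning and the methoxy addition, neither of which moved this assay beyond the scatter. The step of no change at the digits printed from compound 3 to compound 4 (within the scatter) is therefore expected to stay within the scatter, in no particular direction. For compound 4 in this assay the estimate is 1500 nM, with a range from 700 nM to 3200 nM.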

Compound 4, half-maximal inhibitory concentration: 1200 nM
The estimate for compound 4 lay 1.3-fold (0.10 log units) above the measured number; low and high end bracket the measured number.
By their numbers in this assay, from the lowest: compounds 1, 2, 4 and 3 (each within the scatter of the next).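

Adding a chloro ortho to the methoxy group, which gives 3,5-dichloro-4-methoxyphenyl, keeps the number in this assay within the scatter (a 1.3-fold lower number from compound 3 to compound 4 (0.10 log units; within the scatter)). The monochloro comparisons read the same (a 1.1-fold higher number from compound 2 to compound 4 (0.04 log units; within the scatter); a 1.1-fold higher number from compound 1 to compound 4 (0.04 log units; within the scatter)), so the result extends the flat picture to a more heavily substituted aryl group, and no order can be read among the four compounds. No measurement available here accounts for this flatness.

The aryl groups shown carry only chloro and methoxy substituents, so it remains open whether an amine or a nitrile on this ring would move the number beyond the scatter. Also open, as far as these compounds go, is what an amide in place of the carboxylic acid on the shared core would do in this assay.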